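Fluoro Substitution on a Second Core: Expected Growth Inhibition

The source may hold more compounds than are shown below. What is called first, only, known or untested is meant among the compounds shown, and "the series" means these compounds.

Measured compounds:
compound 1, `C=C(C)C(=O)c1ccc(OCc2nc(-c3ccccc3)no2)cc1C`: 6700 nM
compound 2, `C=C(C)C(=O)c1ccc(OCc2nc(-c3ccc(F)cc3)no2)cc1C`: 4600 nM
compound 3, `C=C(CC)C(=O)c1ccc(OCc2nc(-c3ccccc3)no2)c(Cl)c1Cl`: 1700 nM

All three were tested in a functional assay on HL-60 cells (Homo sapiens) for inhibition; a higher number here means a weaker inhibitor of growth, a lower number a stronger inhibitor of growth. Compound 1 and compound 2 share a core and differ by fluoro in place of hydrogen on an aromatic carbon, a change that gave a 1.5-fold lower number from compound 1 to compound 2 (0.16 log units; within the scatter). Compound 3 carries a different core; the difference between the two cores is not broken down here. Compound 4, `C=C(CC)C(=O)c1ccc(OCc2nc(-c3ccc(F)cc3)no2)c(Cl)c1Cl`, is not yet measured. It stands to compound 3 as compound 2 stands to compound 1, differing by fluoro in place of hydrogen on an aromatic carbon, the same change at the same kind of place. Because the earlier step was a 1.5-fold lower number from compound 1 to compound 2 (0.16 log units; within the scatter), the expected step in this assay is a 1.3-fold lower number from compound 3 to compound 4 (0.12 log units; within the scatter), which is estimated to remain within the usual scatter. For compound 4 the estimated value is 1300 nM, lying between 700 nM and 2500 nM.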

Compound 4, concentration for 50% growth inhibition: 1700 nM
The estimate for compound 4 lay 1.3-fold (0.12 log units) below the measured number; the measured number falls inside the stated range.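

In this assay, putting 4-fluorophenyl in place of phenyl gave no change at the digits printed from compound 3 to compound 4 (within the scatter). Set beside the earlier step, the same change reads alike on the two cores: the same change on two cores in this assay, a 1.5-fold lower number (0.16 log units; within the scatter) from compound 1 to compound 2 and no change at the digits printed (within the scatter) from compound 3 to compound 4, 1.5-fold (0.16 log units) apart, within the scatter of two such steps. Among these compounds, this shows only that neither step stands out from the scatter, so the two cores give no sign of treating this change differently; it does not show that the fluoro group is without any effect, or that the agreement would hold on a third core.

The compounds shown leave open whether a different group at the same place, such as methoxy or an amine, would give a step beyond the scatter. They also leave open whether such a step would carry from one core to the other.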